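Aryl urea in place of a benzamide on a pyrazole core

A few compounds are considered here, and "the series" means these few. Any claim that something is new, unique, unknown or untested is made for them only; others in the source may bear on it.

Measured so far:
compound 1, `O=C(Nc1cccc(-n2cc(-c3ccncc3)c(-c3ccc(Cl)c(O)c3)n2)c1)Nc1cccc(C(F)(F)F)c1`: 4690 nM
compound 2, `COc1cc(-c2nn(-c3cccc(NC(=O)Nc4cc(C(F)(F)F)cc(C(F)(F)F)c4)c3)cc2-c2ccncc2)ccc1Cl`: 950 nM
compound 3, `COc1cc(-c2nn(-c3cccc(NC(=O)c4cccc(C(F)(F)F)c4)c3)cc2-c2ccncc2)ccc1Cl`: 2450 nM

In a functional assay on 786-0 cells (Homo sapiens) for inhibition, read by sulforhodamine B assay, with a stated time of 48 h (on this read-out lower numbers stand for stronger inhibition of growth and higher numbers for weaker inhibition of growth), compound 3 gives 2450 nM, the second highest of the three numbers. Compound 1 gives 4690 nM, which lies within the scatter of compound 3, so the two cannot be told apart. Compound 2 gives 950 nM, a lower number beyond the scatter. Compound 4, `COc1cc(-c2nn(-c3cccc(NC(=O)Nc4ccc(Cl)c(Cl)c4)c3)cc2-c2ccncc2)ccc1Cl`, is not yet measured. It differs from compound 3 by (3,4-dichlorophenyl)amino in place of 3-(trifluoromethyl)phenyl on a carbonyl carbon. The step expected in this assay from compound 3 to compound 4 is a moderate move to lower numbers, because compound 2, which also carries a carbamoyl unit on the same core, gives 950 nM. For compound 4 the estimate is 1200 nM, with a range from 400 nM to 3500 nM, a step of a 2.0-fold lower number from compound 3 to compound 4 (0.31 log units; beyond the scatter).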

Compound 4, concentration for 50% growth inhibition: 1310 nM
Compound 4: the middle estimate sits 1.1-fold (0.04 log units) below what was measured; the measured number falls inside the stated range.
By their numbers in this assay, from the lowest: compounds 2, 4, 3 and 1 (each within the scatter of the next, the first and the last beyond it).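

In this assay, replacing the (3-(trifluoromethyl)phenyl)carbonyl of the benzamide with the (3,4-dichlorophenyl)carbamoyl of a urea gives a 1.9-fold lower number from compound 3 to compound 4 (0.27 log units; within the scatter) and so the two compounds cannot be told apart. This position therefore accepts the urea, but the linking unit and the ring substituents were exchanged together, so neither can be credited alone. Nothing available explains this result. Still open, from the compounds shown here alone, is how a urea keeping the 3-(trifluoromethyl)phenyl ring would compare with compound 3, and whether a nitrile or a dimethylamino group in place of the two chlorines would shift growth inhibition beyond the scatter.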